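Adding a (Cyclohexylsulfonyl)methyl Group: Cytotoxicity Outlook

The source may hold more compounds than are shown below. What is called first, only, known or untested is meant among the compounds shown, and "the series" means these compounds.

Of the compounds shown here, three have so far been tested in an ADME assay on HepG2 cells (Homo sapiens) for cytotoxicity, read by MTT assay, with a stated time of 72 h; a higher number here means that more compound is tolerated, a lower number that less compound is tolerated. Compound 1 `COc1ccc(Nc2cc(Cl)cn3c([N+](=O)[O-])c(CS(=O)(=O)c4ccccc4)nc23)cc1` gives > 3900 nM in this assay, which is a limit of the assay rather than a number. Compound 2 `O=[N+]([O-])c1cnc2c(Sc3ccc(Cl)cc3)cc(Cl)cn12` gives > 7800 nM in this assay, again a limit. Compound 3 `O=[N+]([O-])c1c(CS(=O)(=O)c2ccccc2)nc2c([Se]c3ccc(Cl)cc3)cc(Cl)cn12` gives > 7800 nM in this assay, once more a limit. Going by the values given here, because all three values are limits, the single step between compounds that differ in one place, a step that the two limits leave unreadable from compound 1 to compound 3, cannot be read in size or direction. Compound 2 therefore stands simply at the limit of > 7800 nM in this assay, at which 2 of the 3 values shown sit, with nothing to rank it against the others.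

Compound 4 `O=[N+]([O-])c1c(CS(=O)(=O)C2CCCCC2)nc2c(Sc3ccc(Cl)cc3)cc(Cl)cn12` differs from compound 2 by (cyclohexylsulfonyl)methyl in place of hydrogen on an aromatic carbon. Among the compounds with values here, no measured step concerns this kind of change, and the one step on record gives no size to lean on, so the expectation rests on the tolerance already seen. Compound 4 is expected to remain well tolerated, with an estimated 8000 nM in this assay, ranging from 3000 nM to 20000 nM. The estimated step that the limit leaves unreadable from compound 2 to compound 4 is meant as no change beyond the usual scatter, and a further limit rather than a number is the most likely outcome.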

Compound 4, half-maximal cytotoxic concentration: > 31200 nM
Compound 4 ended at the assay's limit (the forecaster's own chance of this, stated with the estimate: 70%); middle value at least 3.9-fold (0.59 log units) away from the limit.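

Compound 4 gives > 31200 nM in this assay, which is again a limit of the assay and not a number. Compound 2 also sits at a limit, so the step between these two compounds cannot be read in size or direction. The compounds shown leave open the concentration at which any of them becomes toxic, and whether the (cyclohexylsulfonyl)methyl group changes tolerance at all.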